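Two-methoxyphenyl Replaces Chlorophenyl on a Bis-Arylidene Core

The source may hold more compounds than are shown below. What is called first, only, known or untested is meant among the compounds shown, and "the series" means these compounds.

Compound 1 `C=CCn1c(=O)/c(=C\c2cccc(Cl)c2)[nH]c(=O)/c1=C\c1ccccc1OC` is tested in a functional assay on HL-60 cells (Homo sapiens) for cytotoxicity, read by CCK-8 assay, with a stated time of 72 h (on this read-out lower numbers stand for stronger inhibition and higher numbers for weaker inhibition), where compound 1 gives 4500 nM, the lowest of the two numbers in the set. Compound 2 `COc1ccccc1/C=c1/[nH]c(=O)/c(=C\c2ccccc2OC)n(C)c1=O`, which carries 2-methoxyphenyl rather than 3-chlorophenyl, gives 16200 nM in this assay. Compound 3 `C=CCn1c(=O)/c(=C\c2ccc(Cl)c(Cl)c2)[nH]c(=O)/c1=C\c1ccccc1OC` is described only as "not active" (no number reported) in this assay, with no number reported. Compound 4 `C=CCn1c(=O)/c(=C\c2ccccc2OC)[nH]c(=O)/c1=C\c1ccccc1OC` differs from compound 1 by 2-methoxyphenyl in place of 3-chlorophenyl on a double-bonded chain carbon bound to an aromatic carbon. Within the data shown here, no measured pair isolates this change, so the account rests on comparison. Because compound 2 gives 16200 nM with 2-methoxyphenyl in that place, a weakening step a 2.2-fold higher number from compound 1 to compound 4 (0.35 log units; beyond the scatter) beyond the scatter is expected. Compound 4 is therefore estimated at 10000 nM, within a range from 3500 nM to 30000 nM.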

Compound 4, half-maximal inhibitory concentration: 15700 nM
Estimate against measurement, compound 4: 1.6-fold (0.20 log units) below; the measured number falls inside the stated range.
By their numbers in this assay, from the lowest: compound 1; then compounds 4 and 2 (each within the scatter of the next).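

In this assay, 2-methoxyphenyl in place of 3-chlorophenyl on a double-bonded chain carbon bound to an aromatic carbon now stands as a measured step (a 3.5-fold higher number from compound 1 to compound 4 (0.54 log units; beyond the scatter)), showing that this place responds to this change. Vinyl in place of hydrogen on a saturated chain carbon bound to an aromatic nitrogen leaves the read-out within the scatter (a 1.0-fold lower number from compound 2 to compound 4 (0.01 log units; within the scatter)). Nothing in the data accounts for either step.

As far as these compounds go, whether 2-chlorophenyl in the first place would read with compound 1 or with compound 4 stays open. So does how a longer chain on the aromatic nitrogen would read.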